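Hydroxymethyl analogue in a weakly active aryl series

The source may report more compounds than this note shows. Statements on the series, on what has been measured and on what is new or still open speak of the compounds shown alone.

Compound 3 `COc1ccc(C(=O)Oc2c(-c3ccccc3)c(-c3ccccc3)n3ccc(C#N)cc23)cc1` has no number in an assay for inhibition of Polyunsaturated fatty acid lipoxygenase ALOX15 (Oryctolagus cuniculus); a lower number here means a stronger inhibitor, a higher number a weaker inhibitor; its entry there reads "not determined" (no result reported). The same holds for compound 1 `CC(O)(c1ccccc1)c1c(-c2ccccc2)c(-c2ccccc2)n2ccc(C#N)cc12`, whose entry in this assay reads "not determined" (no result reported). For the measured compounds named here, the only measured member is compound 2 `N#Cc1ccn2c(-c3ccccc3)c(-c3ccccc3)c(Cc3ccccc3)c2c1`, which in this assay gives 46000 nM, a weak inhibition. Compound 4 `N#Cc1ccn2c(-c3ccccc3)c(-c3ccccc3)c(CO)c2c1` is the next entry to be measured. The change from compound 3 is hydroxymethyl in place of ((4-methoxyphenyl)carbonyl)oxy on an aromatic carbon. Going by the values given here, with no value for compound 3, no step can be stated, and nothing points to a direction beyond the scatter; the benchmark is the weak value of compound 2. On that basis compound 4 is expected to land near 50000 nM, within a range of 10000 nM to 200000 nM, with a real chance that only a limit is reported.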

Compound 4, half-maximal inhibitory concentration: 34000 nM
Estimate against measurement, compound 4: 1.5-fold (0.17 log units) above, and the stated range covers the measured number.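

In this assay, hydroxy in place of phenyl on the saturated chain carbon bound to an aromatic carbon gives a 1.4-fold lower number from compound 2 to compound 4 (0.13 log units; within the scatter), so the two compounds cannot be told apart at this position. Compound 3 has no number, so the step from its ((4-methoxyphenyl)carbonyl)oxy group to hydroxymethyl cannot be read. No supporting evidence bears on this result. Still open, going by these compounds, is whether an amine or a carboxylic acid on this chain carbon, or a longer chain here, would separate from compound 4 beyond the scatter.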